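This account rests on a few compounds, and the source may have more. Where it says the series, first, only, none or still open, it means among the compounds named here.

Of the compounds shown here, two from this series have been tested in a functional assay on TK-10 cells (Homo sapiens) for cytotoxicity, read by sulforhodamine B assay, with a stated time of 48 h, tested at 1 uM (on this read-out lower numbers stand for a stronger effect and higher numbers for a weaker effect at the one concentration tested), and a third is set to follow. Compound 1 `COc1cc(C)cc(-c2nn(CC#N)cc2-c2ccc(-c3cccc(C(C)=O)c3)nc2)c1` gives 2% in this assay. Compound 2 `Cc1cc(O)cc(-c2nn(CC#N)cc2-c2ccnc(-c3ccc(Oc4ccccc4)cc3)c2)c1` gives 19% in this assay, the higher of the two numbers seen so far, standing a clear distance above compound 1. Compound 3 `Cc1cc(O)cc(-c2nn(CC#N)cc2-c2ccnc(-c3ccc(N(C)C)cc3)c2)c1` is the next one to be measured in this assay. It differs from compound 2 at a single point: dimethylamino in place of phenoxy on an aromatic carbon. No pair of measured compounds that differ in only one place is available, so there is no shown step from which the size of this change could be read. On that basis the expected step of a number 1 percentage points higher from compound 2 to compound 3 (within the scatter) is estimated to stay within the usual scatter, with no clear direction. Compound 3 is therefore estimated at 20%, with a range from 5% to 45%.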

Compound 3, a percentage reported as activity, at one concentration (the size of the read-out at that concentration, not a potency): 44%
The estimate for compound 3 lay 24 percentage points below the measured number; low and high end bracket the measured number.
By their numbers in this assay, from the lowest: compound 1; then compound 2; then compound 3.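

In this assay, putting dimethylamino in place of phenoxy on the aromatic carbon para to a large group gives a number 25 percentage points higher from compound 2 to compound 3 (beyond the scatter). For the compounds shown here, this is the first direct comparison, and it shows that the group at this position matters: on this read-out the higher number means a weaker effect, so the swap weakens the effect at the one concentration tested. No measurement shown accounts for this shift.

This single pair changes several things at once, as the ring and the oxygen of phenoxy both leave and the group becomes smaller, so it cannot show which of these changes counts. A methoxy group, a plain amine or a phenyl ring at this position would help to separate them.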